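Cyano for bromo on the aryl sulfonate of compound 2

The compounds below may be only part of what the source reports. "The series", "measured", "known", "first", "only" and "open" are said of these compounds alone.

Compound 1 `O=C(Oc1ccc(-c2cncn2C2CCN(C(=O)c3ccc(Cl)c(C(F)(F)F)c3)CC2)cc1)c1cccc2cnccc12`: in an assay on HEK293 cells for antagonist activity at P2X purinoceptor 7 (Homo sapiens), read by fluorescence, with a stated time of 2 h (a lower number here means a stronger inhibitor, a higher number a weaker inhibitor), compound 1 gives > 10000 nM, which is a limit of the assay rather than a number.
Compound 2 `O=C(c1ccc(Cl)c(C(F)(F)F)c1)N1CCC(n2cncc2-c2ccc(OS(=O)(=O)c3cccc(Br)c3)cc2)CC1`: in this assay compound 2 gives 896 nM.

Compound 2 holds the only number shown in this assay; the other value is a limit (the limit of > 10000 nM in this assay, at which 1 of the 2 values shown sits). Compound 3 `N#Cc1cccc(S(=O)(=O)Oc2ccc(-c3cncn3C3CCN(C(=O)c4ccc(Cl)c(C(F)(F)F)c4)CC3)cc2)c1` differs from compound 2 by cyano in place of bromo on an aromatic carbon. For the measured compounds named here, the one measured step, an at least 11-fold lower number from compound 1 to compound 2 (1.04 log units; beyond the scatter), concerns an exchange at the oxygen on the aromatic ring and not a substituent on the sulfonyl-bearing ring, so no measured step bears directly on the change from compound 2 to compound 3. With nothing to point either way, compound 3 is expected to stay close to compound 2, a step of a 1.1-fold higher number from compound 2 to compound 3 (0.05 log units; within the scatter), which is none beyond the scatter. Compound 3 is therefore estimated at 1000 nM in this assay, with a range from 350 nM to 3000 nM.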

Compound 3, half-maximal inhibitory concentration: 73 nM
Compound 3: middle estimate off by 14-fold (1.14 log units), on the high side; the whole stated range lies above it.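

In this assay the exchange of bromo for cyano gives a 12-fold lower number from compound 2 to compound 3 (1.09 log units; beyond the scatter). The earlier step concerned the whole group on the oxygen on the aromatic ring, whereas this one shows that a single substituent on an aromatic carbon of the sulfonyl-bearing ring, meta to a large group, can by itself carry a large step, and that the total change in that group reaches an at least 130-fold lower number from compound 1 to compound 3 (2.13 log units; beyond the scatter). Compound 1 gives a limit of the assay and not a number, and the step from it is therefore a bound: the limit of > 10000 nM in this assay, at which 1 of the 3 values shown sits.

The compounds shown leave open whether another group at this place, such as a methoxy group, an amine or a carboxylic acid, would give a number like that of cyano or like that of bromo. They also leave open what the plain phenyl sulfonate, with hydrogen at this place, would give.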